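Cyanomethyl in place of 4-cyanobutyl: outlook for compound 3

The compounds below may be only part of what the source reports. "The series", "measured", "known", "first", "only" and "open" are said of these compounds alone.

Compound 1 `COC(=O)C(c1ccccc1)n1nnnc1[C@@H](COCc1ccccc1)NC(=O)C(C)(C)N` gives 20 nM in a functional assay on H4 cells for agonist activity at growth hormone secretagogue receptor type 1 (Homo sapiens), read by FLIPR; on this read-out higher numbers stand for an effect only at larger amounts of compound and lower numbers for an effect already at smaller amounts.
Compound 2 `CC(C)(N)C(=O)N[C@H](COCc1ccccc1)c1nnnn1CCCCC#N` gives 35 nM in this assay.

Compound 2 stands at the higher of the two numbers, with compound 1 nearest: the step of a 1.8-fold higher number from compound 1 to compound 2 (0.24 log units; within the scatter) lies within the scatter. Compound 3 `CC(C)(N)C(=O)N[C@H](COCc1ccccc1)c1nnnn1CC#N` differs from compound 2 by cyano in place of 3-cyanopropyl on a saturated chain carbon bound to an aromatic nitrogen. Going by the values given here, the only measured step, at another place of the molecule, was within the scatter, and no measured pair bears on shortening this chain. The expected step of a 1.4-fold higher number from compound 2 to compound 3 (0.15 log units; within the scatter) is therefore set small, in no firm direction. Compound 3 is estimated at 50 nM, expected between 20 nM and 150 nM.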

Compound 3, half-maximal effective concentration: 29 nM
Compound 3: the middle estimate sits 1.7-fold (0.24 log units) above what was measured; the measured number falls inside the stated range.
By their numbers in this assay, from the lowest: compounds 1, 3 and 2 (each within the scatter of the next).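

Shortening 4-cyanobutyl to cyanomethyl on the aromatic nitrogen gives a 1.2-fold lower number from compound 2 to compound 3 (0.08 log units; within the scatter) in this assay, so the length of this nitrile chain has no readable effect across these two compounds. Cyanomethyl in place of methoxycarbonyl)(benzyl gives a 1.5-fold higher number from compound 1 to compound 3 (0.16 log units; within the scatter) and likewise stays within the scatter. Nothing at hand accounts for this flat result.

On these data alone, whether a butyl chain without the nitrile, an amine or a carboxylic acid on this nitrogen would stay at the same level remains open. As far as these compounds go, a chain longer than 4-cyanobutyl also remains open.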